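The source may hold more compounds than are shown below. What is called first, only, known or untested is meant among the compounds shown, and "the series" means these compounds.

Working notes on the cinnamyl-piperidine amide series. For the measured compounds named here, compound 1 `CC(C)c1ccc(NC(=O)C2CCN(C/C=C/c3ccccc3)CC2)cc1` gives 5200 nM in a functional assay on MGC-803 cells (Homo sapiens) for inhibition, read by MTT assay, with a stated time of 72 h (a lower number here means a stronger inhibitor, a higher number a weaker inhibitor), which places it second highest of the three numbers so far. Compound 2 `CCCCc1ccc(NC(=O)C2CCN(C/C=C/c3ccccc3)CC2)cc1` gives 2570 nM, and the step of a 2.0-fold lower number from compound 1 to compound 2 (0.31 log units; beyond the scatter) is modest. Compound 3 `CN1CCN(c2ccc(NC(=O)C3CCN(C/C=C/c4ccccc4)CC3)cc2)CC1` gives 14000 nM, with a 2.7-fold higher number from compound 1 to compound 3 (0.43 log units; beyond the scatter) and a 5.4-fold higher number from compound 2 to compound 3 (0.74 log units; beyond the scatter), both modest.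

Compound 4 `O=C(NCc1ccccc1)C1CCN(C/C=C/c2ccccc2)CC1` is unmeasured. The change from compound 1 is benzyl in place of 4-isopropylphenyl on an amide-type nitrogen. Going by the values given here, none of the measured steps bears directly on this: every step so far swaps a group on an aromatic carbon while the amide nitrogen keeps its aryl partner, and compound 4 is the first to change that partner. Among the compounds with values here, all three measured steps are modest, so the series has so far moved only within a narrow band, and no measured step gives grounds to expect a large swing in either direction here. The estimate for compound 4 in this assay is 8000 nM, within a range of 2500 nM to 25000 nM, which is expected to mean a step of a 1.5-fold higher number from compound 1 to compound 4 (0.19 log units; within the scatter) that carries wide uncertainty.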

Compound 4, half-maximal inhibitory concentration: > 100000 nM
Compound 4 ended at the assay's limit (the forecaster's own chance of this, stated with the estimate: 15%); middle value at least 12-fold (1.09 log units) away from the limit.
By their numbers in this assay, from the lowest: compound 2; then compound 1; then compound 3. At a limit, above all of these: compound 4.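

Compound 4 stands at a limit of this assay, not at a measured number: the limit of > 100000 nM in this assay, at which 1 of the 4 values shown sits. For the compounds shown here, the amide-type nitrogen is the first place where a single change gives a large step, an at least 19-fold higher number from compound 1 to compound 4 (1.28 log units; beyond the scatter), whereas the three earlier steps, all on an aromatic carbon, are modest. Activity in this assay therefore does not survive benzyl in place of 4-isopropylphenyl, even though both groups carry one six-membered aromatic ring of carbon only.

This change removes the isopropyl group and also inserts a carbon between the ring and the amide-type nitrogen, and the compounds shown do not separate these two parts. Going by these compounds, a plain phenyl on this nitrogen, or a benzyl that keeps an isopropyl or butyl group on its ring, would leave one part in place, and how either behaves remains open.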